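Moving the methyl on the benzyl amide: compound 3 to 4

The source may hold more compounds than are shown below. What is called first, only, known or untested is meant among the compounds shown, and "the series" means these compounds.

In a functional assay on B16 cells (Mus musculus) for inhibition (a lower number here means a stronger inhibitor, a higher number a weaker inhibitor), compound 1 `O=C(/C=C/c1ccc(O)c(O)c1)Nc1cccc(C(F)(F)F)c1` gives 1400 nM and compound 2 `CCCCc1ccc(NC(=O)/C=C/c2ccc(O)c(O)c2)cc1` gives 1200 nM, two values within the scatter of each other. Compound 3 `Cc1ccccc1CNC(=O)/C=C/c1ccc(O)c(O)c1` stands highest of the three at 20000 nM, and its distance to each of the other two lies beyond the scatter.

The next compound is compound 4 `Cc1cccc(CNC(=O)/C=C/c2ccc(O)c(O)c2)c1`, which has the same atoms as compound 3, joined differently. It carries 3-methylphenyl in place of 2-methylphenyl on a saturated chain carbon bound to an amide-type nitrogen.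

For the measured compounds named here, no measured pair differs in one place only, so the data offer no direct precedent for this change. With so little to go on, only a small shift towards a lower number is expected in this assay, most likely none beyond the scatter. The estimated step is a 1.5-fold lower number from compound 3 to compound 4 (0.19 log units; within the scatter). The expected value for compound 4 is 13000 nM, with an estimated range of 4500 nM to 32000 nM.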

Compound 4, half-maximal inhibitory concentration: 3000 nM
Estimate against measurement, compound 4: 4.3-fold (0.64 log units) above, outside the stated range (below it).
By their numbers in this assay, from the lowest: compounds 2 and 1 (each within the scatter of the next); then compound 4; then compound 3.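

Moving the methyl is enough to register in this assay: 3-methylphenyl in place of 2-methylphenyl on a saturated chain carbon bound to an amide-type nitrogen gives a 6.7-fold lower number from compound 3 to compound 4 (0.82 log units; beyond the scatter). For the compounds shown here, this is the first pair that differs in one place. The two compounds have the same atoms, joined differently, with no change in the counts for the group, and this assay still tells them apart. Nothing measured here bears on why the step arises.

Going by these compounds, it remains open how an unsubstituted phenyl, a methoxyphenyl or a chlorophenyl would compare on the same chain carbon. Also open, on these data alone, is whether a longer chain at this place would preserve the step, and compounds 1 and 2 differ from this pair in too many places to settle either question.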